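Hydroxymethyl to formyl in a cytotoxicity test at its limit

The source may hold more compounds than are shown below. What is called first, only, known or untested is meant among the compounds shown, and "the series" means these compounds.

Three related compounds have been tested in a functional assay on HepG2 cells (Homo sapiens) for cytotoxicity, with a stated time of 72 h (on this read-out lower numbers stand for an effect already at smaller amounts and higher numbers for an effect only at larger amounts of compound), and none has yet given an actual number. Compound 1 `C=C[C@@](C)(/C=C/c1ccc(OCc2ccccc2)cc1)CCC=C(C)C` gives > 52000 nM, which is a limit of the assay. Compound 2 `C=C[C@@](C)(/C=C/c1ccc(O)cc1)CC/C=C(\C)C=O` gives > 52000 nM, again a limit. Compound 3 `C=C[C@@](C)(/C=C/c1ccc(O)c(CO)c1)CCC=C(C)C` gives > 52000 nM, also a limit. The picture so far is therefore simple: the limit of > 52000 nM in this assay, at which 3 of the 3 values shown sit.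

Compound 4 `C=C[C@@](C)(/C=C/c1ccc(O)c(C=O)c1)CCC=C(C)C` differs from compound 3 in a single place, with formyl in place of hydroxymethyl on an aromatic carbon, ortho to a hydroxy group and meta to a large group (formyl in place of hydroxymethyl on an aromatic carbon). Among the compounds with values here, no two measured compounds differ in just one place, so the size of this change has to be judged without a direct precedent. All three measured compounds remain at the limit despite their different structures, so a large shift seems unlikely, although a modest move towards effects at smaller amounts is possible. The expected change is small, an at least 1.1-fold lower number from compound 3 to compound 4 (0.06 log units; that floor lies within the scatter). Compound 4 may well give only a limit again in this assay. If it gives a number, compound 4 is estimated at 45000 nM, with an expected range from 15000 nM to 100000 nM.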

Compound 4, half-maximal effective concentration: > 52000 nM
Compound 4: only a limit was reported; the forecaster's own chance of this, stated with the estimate: 60%; at least 1.1-fold (0.06 log units) between middle value and limit.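

Compound 3 and compound 4 both give only a limit in this assay, not a number, and no step can be read for the change from hydroxymethyl to formyl. The compounds shown leave open whether any of them has a measurable effect on these cells, and how they would rank, as all still sit at one value: the limit of > 52000 nM in this assay, at which 4 of the 4 values shown sit.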